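The compounds below may be only part of what the source reports. "The series", "measured", "known", "first", "only" and "open" are said of these compounds alone.

Working notes on the series.

Compound 1, `CSc1cccc(C(=O)N2CCCC(C(=O)Nc3ccc(Cl)cc3)C2)c1`, and compound 2, `C=CCOc1cccc(NC(=O)C2CCCN(C(=O)c3cc(C(F)(F)F)cc(C(F)(F)F)c3)C2)c1`, share a common core and were both tested in an ADME assay on PC-3 cells (Homo sapiens) for cytotoxicity, read by WST assay, tested at 100 uM; on this read-out higher numbers stand for more inhibition at the one concentration tested (going by the name of the read-out) and lower numbers for less inhibition. In this assay compound 1 gives 0%. In this assay, within the data shown here, compound 2 gives 0%, level with compound 1 at the digits reported; no step between the two is recorded, and the two values lie within the scatter of each other, so nothing can be read from the pair beyond the absence of any measurable inhibition at the single concentration tested.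

Compound 3, `O=C(Nc1cccc(S(=O)(=O)N2CCCC2)c1)C1CCCN(C(=O)c2cc(C(F)(F)F)cc(C(F)(F)F)c2)C1`, has not yet been measured in this assay. Relative to compound 2 it carries (pyrrolidin-1-yl)sulfonyl in place of allyloxy on an aromatic carbon, that is, (pyrrolidin-1-yl)sulfonyl in place of allyloxy on an aromatic carbon, meta to a large group.

With both measured compounds showing no inhibition, the step of a number 3 percentage points higher from compound 2 to compound 3 (within the scatter) is expected to be none beyond the scatter. Compound 3 is therefore estimated at 3% in this assay, with a range from 0% to 15%.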

Compound 3, a percentage reported as inhibition, at one concentration (the size of the read-out at that concentration, not a potency): 0%
Beside the measured number, compound 3's estimate is 3 percentage points above it; the range from low to high includes it.
By their numbers in this assay, from the lowest: compounds 1, 2 and 3 (each within the scatter of the next).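

In this assay, among these compounds, the one-place change of (pyrrolidin-1-yl)sulfonyl in place of allyloxy, on an aromatic carbon, meta to a large group, gives no change at the digits printed from compound 2 to compound 3 (within the scatter), and this is the only step that can be read between compounds differing in one place. At this position, then, the read-out does not separate allyloxy, with 4 heavy atoms, no ring and 1 hydrogen-bond acceptor, from (pyrrolidin-1-yl)sulfonyl, with 8 heavy atoms, a five-membered non-aromatic ring and 2 hydrogen-bond acceptors, even though the two groups differ this much in these counts. No supporting measurement is available to explain this result.

On these data alone, whether an amine or a carboxylic acid on this same aromatic carbon would give a number beyond the scatter from that of compound 3 remains open. Also open is whether a change elsewhere on compound 3, such as a longer chain in place of a trifluoromethyl group, would move the read-out at all, since the single step shown covers one position only.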